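Swapping Fluoro for Chloro on a Carbamate Aryl Ring

The source may hold more compounds than are shown below. What is called first, only, known or untested is meant among the compounds shown, and "the series" means these compounds.

Measured compounds:
compound 1 `CC(C)=CCC1Cc2c(OC(=O)Nc3ccc(F)c(Cl)c3)cc(=O)n(CCCO)c2CC1(C)C` gives 0%
compound 2 `CC(C)=CCC1Cc2c(OC(=O)Nc3ccc(Cl)c(Cl)c3)cc(=O)n(CCCO)c2CC1(C)C` gives 1.8%
compound 3 `CC(C)=CCC/C(C)=C/CC1Cc2c(OC(=O)Nc3ccc(F)c(F)c3)cc(=O)n(CCCO)c2CC1(C)C` gives 4.8%

All three were tested in a functional assay on PANC-1 cells (Homo sapiens) for inhibition, read by MTT assay, with a stated time of 24 h, tested at 10 uM; on this read-out lower numbers stand for less inhibition and higher numbers for more inhibition at the one concentration tested (going by the name of the read-out). Compound 1 and compound 2 share a core and differ by chloro in place of fluoro on an aromatic carbon, and that change gave a number 1.8 percentage points higher from compound 1 to compound 2 (within the scatter), so the two numbers cannot be told apart. Compound 3 sits on a different core, and the difference between the two cores is not broken down here; its value and those of compound 1 and compound 2 all lie within the scatter of one another.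

Compound 4 `CC(C)=CCC/C(C)=C/CC1Cc2c(OC(=O)Nc3ccc(F)c(Cl)c3)cc(=O)n(CCCO)c2CC1(C)C` is the still untested partner of compound 3, differing by chloro in place of fluoro on an aromatic carbon. This is the same kind of change as that from compound 1 to compound 2, but not the same: there the entering chloro was ortho to a chloro group and para to a large group, here it is ortho to a fluoro group and meta to a large group. Because a number 1.8 percentage points higher from compound 1 to compound 2 (within the scatter) stayed within the scatter, the step from compound 3 to compound 4 is expected to be similarly small, about a number 1.2 percentage points higher from compound 3 to compound 4 (within the scatter). Compound 4 is therefore estimated at 6%, with a likely range from 0% to 15%.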

Compound 4, a percentage reported as inhibition, at one concentration (the size of the read-out at that concentration, not a potency): 0%
For compound 4 the middle estimate is 6 percentage points above the measured one, within the range that was stated.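

In this assay, chloro in place of fluoro on an aromatic carbon gave a number 4.8 percentage points lower from compound 3 to compound 4 (within the scatter), and set beside the same change on the other core, the two results cannot be told apart: the same change on two cores in this assay, a number 1.8 percentage points higher (within the scatter) from compound 1 to compound 2 and a number 4.8 percentage points lower (within the scatter) from compound 3 to compound 4, 6.6 percentage points apart, within the scatter of two such steps. The two cores themselves differ by 3-methylbut-2-en-1-yl in place of hydrogen on a saturated chain carbon bound to a double-bonded chain carbon, which gave no change at the digits printed from compound 1 to compound 4 (within the scatter). For the compounds shown here, this shows only that the change made no readable difference on either core; with all four numbers this small and only two pairs to compare, it does not show that the change would carry over in the same way to a compound with clear inhibition.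

Still open, on these data alone, is whether a group other than fluoro or chloro on that aromatic ring, such as methoxy or a nitrile, would give a clearly higher number. Also open, as far as these compounds go, is what an amine or a carboxylic acid in place of the hydroxyl at the end of the propyl chain would do.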